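The Same Fluorine Shift on Two Related Cores

This account rests on a few compounds, and the source may have more. Where it says the series, first, only, none or still open, it means among the compounds named here.

Compound 1, `Oc1cccc(-c2cc(-c3cccc(F)c3)cc(-c3cccc(O)c3)n2)c1`: 1400 nM
Compound 2, `Oc1cccc(-c2cc(-c3ccc(F)cc3)cc(-c3cccc(O)c3)n2)c1`: 1280 nM
Compound 3, `Oc1ccc(-c2cc(-c3cccc(F)c3)cc(-c3ccc(O)cc3)n2)cc1`: > 50000 nM

In a functional assay on HeLa cells (Homo sapiens) for inhibition (on this read-out higher numbers stand for weaker inhibition and lower numbers for stronger inhibition), compound 1 gives 1400 nM and compound 2 gives 1280 nM. The two differ only in one change, (4-fluorophenyl in place of 3-fluorophenyl on an aromatic carbon), and the step of a 1.1-fold lower number from compound 1 to compound 2 (0.04 log units; within the scatter) is small enough to count as no real change.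

Compound 3 carries a different core, and in this assay compound 3 reaches only the limit of the assay, > 50000 nM; this is a limit and not a number, the one described by the limit of > 50000 nM in this assay, at which 1 of the 3 values shown sits. How the core of compound 3 differs from the core of compound 1 is not broken down here.

Compound 4, `Oc1ccc(-c2cc(-c3ccc(F)cc3)cc(-c3ccc(O)cc3)n2)cc1`, is not yet measured. It arises from compound 3 by 4-fluorophenyl in place of 3-fluorophenyl on an aromatic carbon. Among the measured compounds shown here, this is the same kind of change as the one from compound 1 to compound 2, though not the same: in the first case the fluorophenyl sits meta to two 3-hydroxyphenyl groups, here it sits meta to two 4-hydroxyphenyl groups.

Since the step of a 1.1-fold lower number from compound 1 to compound 2 (0.04 log units; within the scatter) stayed within the scatter, the step from compound 3 to compound 4 is expected to be of similar size, a step that the limit leaves unreadable from compound 3 to compound 4, so compound 4 is expected to land at about 60000 nM in this assay, most likely again reported only as a limit.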

Compound 4, half-maximal inhibitory concentration: 8680 nM
Compound 4: middle estimate off by 6.9-fold (0.84 log units), on the high side, outside the stated range (below it).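

In this assay, the swap of 3-fluorophenyl for 4-fluorophenyl gives an at least 5.7-fold lower number from compound 3 to compound 4 (0.76 log units; beyond the scatter), whereas the same swap on the core of compound 1 gives a 1.1-fold lower number from compound 1 to compound 2 (0.04 log units; within the scatter), so the two cores do not respond alike: the same change on two cores in this assay, a 1.1-fold lower number (0.04 log units; within the scatter) from compound 1 to compound 2 and an at least 5.7-fold lower number (0.76 log units; beyond the scatter) from compound 3 to compound 4, at least 5.2-fold (0.72 log units) apart, beyond the scatter of two such steps

A change that seems to do nothing on one core can therefore still matter on a related one, and the result on the core of compound 1 would have been a poor guide to the result on the core of compound 3. These four compounds show neither why the cores part ways nor how large the step truly is, since compound 3 is known only as a limit and not as a number: the limit of > 50000 nM in this assay, at which 1 of the 4 values shown sits.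

Among the compounds shown here, with a single swap on only two cores, it remains unknown whether this difference between the cores is particular to the fluorine shift or would also appear with other changes. A 4-chlorophenyl or 4-methoxyphenyl group in the same place, opposite the ring nitrogen, could test this, as could an amine in place of the hydroxyl groups.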